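This account rests on a few compounds, and the source may have more. Where it says the series, first, only, none or still open, it means among the compounds named here.

Measured so far:
compound 1 `COc1cc(C(=O)c2sc(Nc3ccc(F)cc3)nc2N)cc(OC)c1OC`: 58 nM
compound 2 `COc1cc(C(=O)c2sc(Nc3ccc(C)cc3)nc2N)cc(OC)c1OC`: 15 nM
compound 3 `Nc1nc(Nc2ccc(F)cc2)sc1C(=O)c1ccccc1`: > 10000 nM

All three were tested in a functional assay on FM3A cells (Mus musculus) for antiproliferative activity, read by cell counting, with a stated time of 2 days; on this read-out higher numbers stand for weaker inhibition and lower numbers for stronger inhibition. Compound 1 and compound 2 share one core and differ in a single place: methyl in place of fluoro on an aromatic carbon. That change gave a 3.9-fold lower number from compound 1 to compound 2 (0.59 log units; beyond the scatter). Compound 3 has a different core; how the two cores differ is not broken down here. For compound 3 the read-out is a limit, not a number, (the limit of > 10000 nM in this assay, at which 1 of the 3 values shown sits).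

Compound 4 `Cc1ccc(Nc2nc(N)c(C(=O)c3ccccc3)s2)cc1` has not yet been measured in this assay. It stands to compound 3 exactly as compound 2 stands to compound 1: methyl in place of fluoro on an aromatic carbon, the same change. On the first core that change produced a 3.9-fold lower number from compound 1 to compound 2 (0.59 log units; beyond the scatter). Here the starting point is a limit, so the size of the step cannot be anchored to a measured number, and even a step of the same size would leave compound 4 close to that limit. The step is expected to be an at least 1.6-fold lower number from compound 3 to compound 4 (0.22 log units; that floor lies within the scatter). Compound 4 is expected to give 6000 nM, most likely between 1500 nM and 30000 nM, with a real chance that only a limit is reported again.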

Compound 4, half-maximal inhibitory concentration: 1500 nM
Beside the measured number, compound 4's estimate is 4.0-fold (0.60 log units) above it; the measured number falls inside the stated range.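

In this assay compound 3 gives > 10000 nM, which is a limit and not a number. Going from 4-fluorophenyl to 4-methylphenyl on the second core gave an at least 6.6-fold lower number from compound 3 to compound 4 (0.82 log units; beyond the scatter), so the same swap moved the number in the same direction, towards stronger inhibition, on both cores shown, although two pairs are a small base for any rule. This shows that the direction carried over from one core to the other, but it does not show that the size of the step carried over: the same change on two cores in this assay, a 3.9-fold lower number (0.59 log units; beyond the scatter) from compound 1 to compound 2 and an at least 6.6-fold lower number (0.82 log units; beyond the scatter) from compound 3 to compound 4; the limit leaves it open whether they differ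

The compounds shown leave open how a measured starting value on the second core would change the size of this step, and whether the direction would hold on a third core. They also leave open what other groups in the same place on the ring would do, such as a chloro, a methoxy or an amine, compared with fluoro and methyl.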